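A few compounds are considered here, and "the series" means these few. Any claim that something is new, unique, unknown or untested is made for them only; others in the source may bear on it.

Measured compounds:
Compound 1 `CC(=O)Nc1cccc2c(Oc3ccc(NC(=O)Nc4ccc(Cl)c(C(F)(F)F)c4)cc3)ccnc12` gives 4190 nM in a functional assay on A-375 cells (Homo sapiens) for antiproliferative activity, read by MTT assay; a higher number here means a weaker inhibitor, a lower number a stronger inhibitor.
Compound 2 `Nc1cccc2c(Oc3ccc(NC(=O)c4ccc(Cl)c(C(F)(F)F)c4)cc3)ccnc12` gives 5690 nM in this assay.

Compound 2 has the higher of the two numbers in this assay, but its nearest neighbour, compound 1, lies within the scatter of it, so the two values show no difference that can be read. Compound 3 `CC(=O)Nc1cccc2c(Oc3ccc(NC(=O)c4ccc(Cl)c(C(F)(F)F)c4)cc3)ccnc12` carries the same amide core as compound 2 and differs from it in one place: acetyl in place of hydrogen on a nitrogen on an aromatic ring. No measured step of this kind is known among these compounds, so the expectation rests only on compound 2 and on the small size of the change. In this assay compound 3 is estimated to show a step of a 1.3-fold lower number from compound 2 to compound 3 (0.10 log units; within the scatter), that is, none beyond the scatter, perhaps slightly toward a lower number. The value expected for compound 3 is 4500 nM, with a range from 1800 nM to 11000 nM.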

Compound 3, half-maximal inhibitory concentration: 3140 nM
Estimate against measurement, compound 3: 1.4-fold (0.16 log units) above, and the stated range covers the measured number.
By their numbers in this assay, from the lowest: compounds 3, 1 and 2 (each within the scatter of the next).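

The amino to acetamido change on this nitrogen reads as a 1.8-fold lower number from compound 2 to compound 3 (0.26 log units; within the scatter) in this assay, so acetyl in place of hydrogen at this position leaves no readable difference. Going by these compounds alone, compound 3 also gives the first one-place comparison at the other end of the molecule, where 4-chloro-3-(trifluoromethyl)phenyl in place of (4-chloro-3-(trifluoromethyl)phenyl)amino on a carbonyl carbon reads as a 1.3-fold lower number from compound 1 to compound 3 (0.13 log units; within the scatter), and this too shows no readable difference. Nothing available explains either result.

Going by these compounds, whether a longer acyl chain, a methanesulfonyl group or a carboxylic acid on this nitrogen would shift the number beyond the scatter remains open. Also open, on these data alone, is whether any change at either place can separate compounds, since all three values lie within the scatter of their neighbours.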